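Compound 3 and the cytotoxicity of its two relatives

The source may hold more compounds than are shown below. What is called first, only, known or untested is meant among the compounds shown, and "the series" means these compounds.

Measured in an ADME assay on L6 cells (Rattus norvegicus) for cytotoxicity; a lower number here means a stronger inhibitor, a higher number a weaker inhibitor:
compound 1 `O=C(CN1CCCC1)OC1CC2(N3CCCC3)CC(c3ccccc3)C1C(c1ccccc1)C2`: 42900 nM
compound 2 `O=C(CCN1CCCCC1)OC1CC2(N3CCCC3)CC(c3ccccc3)C1C(c1ccccc1)C2`: 17800 nM

Of the two compounds measured in this assay, compound 2 has the lower number, at 17800 nM. Compound 3 `O=C(CN1CCC(O)CC1)OC1CC2(N3CCCC3)CC(c3ccccc3)C1C(c1ccccc1)C2` departs from it as follows: 4-hydroxypiperidin-1-yl in place of (piperidin-1-yl)methyl on a saturated chain carbon bound to a carbonyl carbon. For the measured compounds named here, only one measured step bears on this change, the modest 2.4-fold lower number from compound 1 to compound 2 (0.38 log units; beyond the scatter), which was made at the same place. Going by the values given here, no measured compound carries 4-hydroxypiperidin-1-yl, so the reasoning is tentative. A step of similar size towards a higher number is expected. The expected step is a 2.1-fold higher number from compound 2 to compound 3 (0.33 log units; beyond the scatter). For compound 3 the estimate is 38000 nM, with an expected range of 15000 nM to 90000 nM.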

Compound 3, half-maximal inhibitory concentration: 93400 nM
For compound 3 the middle estimate is 2.5-fold (0.39 log units) below the measured one; measured number above the stated range.
By their numbers in this assay, from the lowest: compound 2; then compound 1; then compound 3.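

In this assay, 4-hydroxypiperidin-1-yl on a saturated chain carbon bound to a carbonyl carbon gives the highest number of the three, with one step (a 5.2-fold higher number from compound 2 to compound 3 (0.72 log units; beyond the scatter)) and a smaller one (a 2.2-fold higher number from compound 1 to compound 3 (0.34 log units; beyond the scatter)). This place therefore moves the number upward as well as downward, which the earlier step alone did not show. No supporting evidence bears on this result.

The compounds shown leave open whether the hydroxyl or the shorter chain carries the rise from compound 2 to compound 3. They also leave open how a 4-methoxypiperidin-1-yl or a morpholin-4-yl group would read here.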